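The source may report more compounds than this note shows. Statements on the series, on what has been measured and on what is new or still open speak of the compounds shown alone.

Measured compounds: compound 1 `CC(C)C(/C=C1\NC(=O)NC1=O)c1ccc(-c2ccc3cccc(F)c3c2)[nH]c1=O` and compound 2 `CC(C)C(/C=C1\SC(=O)NC1=O)c1ccc(-c2ccc3cccc(F)c3c2)[nH]c1=O`.

In an assay on membranes from Chem-1 cells for displacement of a labelled ligand from prostaglandin E2 receptor EP3 subtype (Homo sapiens), read by scintillation counting, with a stated time of 2 h (a higher number here means a weaker inhibitor, a lower number a stronger inhibitor), compound 1 gives 43 nM. In this assay, among the compounds with values here, compound 2 gives 13 nM, the lowest of the two numbers, with compound 1 its only neighbour; the step of a 3.3-fold lower number from compound 1 to compound 2 (0.52 log units; beyond the scatter) separates them.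

Compound 3 `CC(C)C(/C=C1/C(=O)NC(=O)N1C)c1ccc(-c2ccc3cccc(F)c3c2)[nH]c1=O` differs from compound 2 by a group of 9 heavy atoms (5 carbon, 2 nitrogen, 2 oxygen; one five-membered non-aromatic ring with 2 hetero atoms) in place of a group of 8 heavy atoms (4 carbon, 1 nitrogen, 2 oxygen, 1 sulfur; one five-membered non-aromatic ring with 2 hetero atoms), on a saturated chain carbon bound to an aromatic carbon and a saturated chain carbon. Within the data shown here, no measured step covers this exchange directly; the only step on record, a 3.3-fold lower number from compound 1 to compound 2 (0.52 log units; beyond the scatter), concerns the other ring in the same place and went the opposite way. The change from compound 2 to compound 3 is therefore expected to give a step of a 3.1-fold higher number from compound 2 to compound 3 (0.49 log units; beyond the scatter) in this assay, with wide uncertainty. For compound 3 the estimate in this assay is 40 nM, within 12 nM to 150 nM.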

Compound 3, inhibition constant: 6 nM
The estimate for compound 3 lay 6.7-fold (0.82 log units) above the measured number; measured number below the stated range.
By their numbers in this assay, from the lowest: compound 3; then compound 2; then compound 1.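

Methyl in place of hydrogen on an amide-type nitrogen in a ring gives a 7.2-fold lower number from compound 1 to compound 3 (0.86 log units; beyond the scatter) in this assay, so this ring nitrogen accepts a substituent at this position on the saturated chain carbon. The change from the sulfur-containing ring gives a 2.2-fold lower number from compound 2 to compound 3 (0.34 log units; beyond the scatter) in the same assay, so among these three compounds sulfur in the ring is not needed for the lowest number. From the compounds shown here alone, whether an ethyl group, a longer chain or a chain ending in a carboxylic acid on that nitrogen would lower the number further remains open. No available evidence bears on the reason for either step.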